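Pyrimidine ether series: benzyl variation and cytotoxicity

A few compounds are considered here, and "the series" means these few. Any claim that something is new, unique, unknown or untested is made for them only; others in the source may bear on it.

Measured so far:
Compound 1 `CCOC(=O)c1cnc(N2CCN(Cc3cccc(C(F)(F)F)c3)CC2)nc1Oc1c(C)cc(-c2ccc(C#N)cc2)cc1C`. In an ADME assay on MT4 cells (Homo sapiens) for cytotoxicity, read by MTT assay, with a stated time of 4 days (on this read-out lower numbers stand for higher toxicity in this test and higher numbers for lower toxicity in this test), compound 1 gives > 125000 nM, a limit of the assay.
Compound 2 `CCOC(=O)c1cnc(N2CCN(Cc3ccc(C(N)=O)cc3)CC2)nc1Oc1c(C)cc(-c2ccc(C#N)cc2)cc1C`. In this assay compound 2 gives 66500 nM.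
Compound 3 `CCOC(=O)c1cnc(N2CCN(Cc3cccc(C(N)=O)c3)CC2)nc1Oc1c(C)cc(-c2ccc(C#N)cc2)cc1C`. In this assay compound 3 gives 14800 nM.

Compound 1 stands only at a limit, (the limit of > 125000 nM in this assay, at which 1 of the 3 values shown sits), so no exact number is known for it. Compound 4 `CCOC(=O)c1cnc(N2CCN(Cc3ccc(S(N)(=O)=O)cc3)CC2)nc1Oc1c(C)cc(-c2ccc(C#N)cc2)cc1C` has not yet been measured. It differs from compound 1 in one place: 4-sulfamoylphenyl in place of 3-(trifluoromethyl)phenyl on a saturated chain carbon bound to an amine nitrogen in a ring.

Of the measured steps, the closest is an at least 1.8-fold lower number from compound 1 to compound 2 (0.27 log units; that floor lies within the scatter), where compound 2 carries 4-carbamoylphenyl at the same place that compound 4 carries 4-sulfamoylphenyl. The other steps, an at least 8.4-fold lower number from compound 1 to compound 3 (0.92 log units; beyond the scatter) and a 4.5-fold lower number from compound 2 to compound 3 (0.65 log units; beyond the scatter), concern 3-carbamoylphenyl and point the same way, toward lower numbers. A step toward lower numbers is therefore expected for compound 4, of roughly the size seen for compound 2, though the limit for compound 1 leaves the floor of that step open.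

The estimate for compound 4 in this assay is 60000 nM, with a range of 20000 nM to 125000 nM; this corresponds to an expected at least 2.0-fold lower number from compound 1 to compound 4 (0.31 log units; beyond the scatter).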

Compound 4, half-maximal cytotoxic concentration: >= 7930 nM
Compound 4: no number, only a limit (the forecaster's own chance of this, stated with the estimate: 25%); the middle value does not contradict the limit.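

In this assay compound 4 gives >= 7930 nM, a limit and not a number. Its steps from compound 1, compound 2 and compound 3 therefore cannot be read. The compounds shown leave open whether 4-sulfamoylphenyl and 4-carbamoylphenyl differ at all on this read-out.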